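The compounds below may be only part of what the source reports. "The series", "measured", "known", "first", "only" and "open" are said of these compounds alone.

Measured compounds:
Compound 1, `Cc1cc(S(=O)(=O)/N=C(\N)N/N=C/C#Cc2ccccc2)c(SCc2ccccc2)cc1Cl`, gives 5000 nM in a functional assay on HeLa cells (Homo sapiens) for antiproliferative activity, read by MTT assay, with a stated time of 72 h; on this read-out lower numbers stand for stronger inhibition and higher numbers for weaker inhibition.
Compound 2, `C/C(C#Cc1ccccc1)=N\N/C(N)=N/S(=O)(=O)c1cc(C)c(Cl)cc1SCc1ccccc1`, gives 6000 nM in this assay.
Compound 3, `Cc1cccc(CSc2cc(Cl)c(C)cc2S(=O)(=O)/N=C(\N)N/N=C/C#Cc2ccccc2)c1`, gives 11000 nM in this assay.

Among these three numbers compound 2 stands second highest. The nearest number belongs to compound 1: a 1.2-fold higher number from compound 1 to compound 2 (0.08 log units; within the scatter). The number of compound 3 is further off, but that gap also lies within the scatter, so the three measured compounds cannot be ranked against one another on these data.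

Compound 4, `C/C(C#Cc1ccccc1)=N\N/C(N)=N/S(=O)(=O)c1cc(C)c(Cl)cc1SCc1ccc(C)cc1`, has not yet been measured. It differs from compound 2 in one place: methyl in place of hydrogen on an aromatic carbon. One measured step is of the same kind and therefore bears on it: a 2.2-fold higher number from compound 1 to compound 3 (0.34 log units; beyond the scatter). That step was modest but beyond the scatter, and it raised the number, meaning weaker inhibition. On that single precedent a step of similar size and direction is expected for compound 4 in this assay, namely a 2.0-fold higher number from compound 2 to compound 4 (0.30 log units; within the scatter). Compound 4 is thus estimated at 12000 nM, with a range from 5000 nM to 30000 nM.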

Compound 4, half-maximal inhibitory concentration: 110000 nM
Estimate against measurement, compound 4: 9.2-fold (0.96 log units) below, outside the stated range (above it).
By their numbers in this assay, from the lowest: compounds 1, 2 and 3 (each within the scatter of the next, the first and the last beyond it); then compound 4.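

Replacing benzyl with 4-methylbenzyl on the core of compound 2 gives an 18-fold higher number from compound 2 to compound 4 (1.26 log units; beyond the scatter) in this assay, a large loss of inhibition. Among these compounds, one added methyl on this ring can therefore matter a great deal, which the earlier compounds did not reveal. Nor does this kind of change have a fixed size from one core to another: the same change on two cores in this assay, a 2.2-fold higher number (0.34 log units; beyond the scatter) from compound 1 to compound 3 and an 18-fold higher number (1.26 log units; beyond the scatter) from compound 2 to compound 4, 8.3-fold (0.92 log units) apart, beyond the scatter of two such steps

The methyl of compound 3 stands on a different ring carbon from that of compound 4, and the two cores also differ, so the compounds shown cannot separate these two differences as the source of the gap. On these data alone, it also remains open whether another group at this place, such as chlorine or methoxy, would weaken inhibition as strongly as methyl does here.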